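This account rests on a few compounds, and the source may have more. Where it says the series, first, only, none or still open, it means among the compounds named here.

Measured compounds:
- compound 1, `COc1cccc(C2=NNC(c3ccc(Cl)cc3)C2O)c1`, 49 nM in a functional assay on MCF7 cells (Homo sapiens) for antiproliferative activity, read by sulforhodamine B assay, with a stated time of 48 h; a higher number here means a weaker inhibitor, a lower number a stronger inhibitor
- compound 2, `COc1ccc(C2=NN(c3ccccc3)C(c3ccc(F)cc3)C2O)cc1`, 16 nM

Compound 1 gives the highest of the two numbers in this assay; the nearest is compound 2, whose number is lower by a gap beyond the usual scatter. Compound 3, `COc1cccc(C2=NNC(c3ccc(Br)cc3)C2O)c1`, is not yet measured. It differs from compound 1 by bromo in place of chloro on an aromatic carbon. Going by the values given here, no measured pair shows this kind of change, so nothing here fixes its size. A step of this kind is expected to stay close to the scatter in either direction. Compound 3 is therefore expected to give about 45 nM, between 20 nM and 110 nM, a step of a 1.1-fold lower number from compound 1 to compound 3 (0.04 log units; within the scatter) that is expected to be small.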

Compound 3, half-maximal inhibitory concentration: 49 nM
Compound 3: middle estimate off by 1.1-fold (0.04 log units), on the low side, within the range that was stated.
By their numbers in this assay, from the lowest: compound 2; then compounds 1 and 3 (each within the scatter of the next).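

In this assay, going by these compounds alone, the change from 4-chlorophenyl to 4-bromophenyl gives no change at the digits printed from compound 1 to compound 3 (within the scatter), the first direct reading of a single change at this position. Here, on this core, bromo can stand in for chloro on the aromatic carbon without a readable shift in the number. Nothing measured here explains why the two halogens match.

As far as these compounds go, it remains open whether a group other than a halogen, such as an amine or a carboxylic acid, would hold the number at this position. Iodo at the same place is equally open.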